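Trimethoxyphenyl to Chlorophenyl: Expected Cytotoxicity of Compound 4

A few compounds are considered here, and "the series" means these few. Any claim that something is new, unique, unknown or untested is made for them only; others in the source may bear on it.

Compound 1, `COc1ccc(-c2cc(-c3ccc(C4NC(=O)c5ccccc5N4)cc3)nc(N)n2)cc1`: 124000 nM
Compound 2, `COc1cc(-c2cc(-c3ccc(C4NC(=O)c5ccccc5N4)cc3)nc(N)n2)cc(OC)c1OC`: 85900 nM
Compound 3, `CC1(c2ccc(Nc3nc(N4CCc5ccccc5C4)nc(N4CCc5ccccc5C4)n3)cc2)NC(=O)c2ccccc2N1`: > 400000 nM

Of the compounds shown here, three have been measured in an ADME assay on Vero cells (Chlorocebus sabaeus) for cytotoxicity, read by MTT assay, with a stated time of 72 h; on this read-out higher numbers stand for lower toxicity in this test and lower numbers for higher toxicity in this test. Compound 1 gives 124000 nM in this assay. Where compound 1 carries a 4-methoxyphenyl, a 3,4,5-trimethoxyphenyl is carried by compound 2, which gives 85900 nM. The step of a 1.4-fold lower number from compound 1 to compound 2 (0.16 log units; within the scatter) shows that these two numbers lie within the scatter of each other, so neither can be called more or less toxic than the other. For compound 3, built on a different core, this assay reports only a limit, (the limit of > 400000 nM in this assay, at which 1 of the 3 values shown sits), and not a number.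

Compound 4, `Nc1nc(-c2ccc(Cl)cc2)cc(-c2ccc(C3NC(=O)c4ccccc4N3)cc2)n1`, has not yet been measured in this assay. It differs from compound 2 in one place: 4-chlorophenyl in place of 3,4,5-trimethoxyphenyl on an aromatic carbon. Within the data shown here, the only measured step of this kind, the exchange of one group at this same aromatic carbon between compound 1 and compound 2, stayed within the scatter. On that basis no change beyond the scatter is expected here either, in either direction. Compound 4 is therefore estimated at 100000 nM in this assay, in a range from 40000 nM to 250000 nM. The step that this estimate implies, a 1.2-fold higher number from compound 2 to compound 4 (0.07 log units; within the scatter), is expected to stay within the scatter.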

Compound 4, half-maximal cytotoxic concentration: 323000 nM
Estimate against measurement, compound 4: 3.2-fold (0.51 log units) below; measured number outside the range, above it.
By their numbers in this assay, from the lowest: compounds 2 and 1 (each within the scatter of the next); then compound 4. At a limit, above all of these: compound 3.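

In this assay the group on this aromatic carbon turns out to matter, which the first pair could not show: 4-chlorophenyl in place of 3,4,5-trimethoxyphenyl moves the number clearly (a 3.8-fold higher number from compound 2 to compound 4 (0.58 log units; beyond the scatter)), and chloro in place of methoxy does so as well (a 2.6-fold higher number from compound 1 to compound 4 (0.42 log units; beyond the scatter)). The earlier exchange (a 1.4-fold lower number from compound 1 to compound 2 (0.16 log units; within the scatter)) stayed within the scatter, so adding methoxy groups to the ring made no readable difference, whereas the group with chloro and no methoxy stands apart from both methoxy-bearing compounds, on the side of lower toxicity in this test. Nothing shown here explains why this exchange goes with a higher number.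

The compounds shown cannot separate the gain from having chloro from the gain from losing methoxy, and a plain phenyl ring on this carbon would be the group that speaks to that question. As far as these compounds go, it also stays open whether other groups on the phenyl ring, such as fluoro, an amine or a carboxylic acid, would give numbers close to that of compound 4 or close to those of the methoxy-bearing pair.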